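This account rests on a few compounds, and the source may have more. Where it says the series, first, only, none or still open, it means among the compounds named here.

In an in vitro ADME assay on microsomes from liver (Homo sapiens) for metabolic stability, tested at 5 uM (on this read-out lower numbers stand for a shorter-lived compound and higher numbers for a longer-lived compound), compound 3 (`CC(C)(C)CCn1nc(-c2cccs2)c(O)c(C2=NS(=O)(=O)c3cc(NS(C)(=O)=O)ccc3N2)c1=O`) gives > 1 h as its reading, which is a limit of the assay and not a number. Compound 3 is therefore the one entry at the limit of > 1 h in this assay, at which 1 of the 3 values shown sits, in the series.

The numeric readings come from compounds that differ from compound 3 in more than one place. In this assay compound 1 (`CC(C)CCn1nc(-c2cccs2)c(O)c(C2=NS(=O)(=O)c3cc(N(C)S(C)(=O)=O)ccc3N2)c1=O`) gives 0.467 h as its half-life. In this assay compound 2 (`CC(C)CCn1nc(CC(C)C)c(O)c(C2=NS(=O)(=O)c3cc(NS(C)(=O)=O)ccc3N2)c1=O`) gives 0.123 h as its half-life.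

The next entry is compound 4 (`CC(C)Cn1nc(-c2cccs2)c(O)c(C2=NS(=O)(=O)c3cc(NS(C)(=O)=O)ccc3N2)c1=O`), which carries isopropyl in place of neopentyl on a saturated chain carbon bound to an aromatic nitrogen. Going by the values given here, no measured pair isolates this change, so its size has to be judged indirectly. The nearest guide is compound 1 with its reading of 0.467 h in this assay and this anchors the expectation of a shorter half-life for compound 4.

The expected change is an at least 2.0-fold lower number from compound 3 to compound 4 (0.30 log units; that floor lies within the scatter) in this assay and it is expected to point toward a shorter half-life, probably beyond the usual scatter.

For compound 4 the estimated half-life is 0.5 h with an expected range from 0.2 h to 1 h in this assay as the likely outcome.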

Compound 4, half-life: > 1 h
Compound 4 was reported as a limit; the forecaster's own chance of this, stated with the estimate: 15%; at least 2.0-fold (0.30 log units) between middle value and limit.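

In this assay compound 4 gives > 1 h, which is a limit of the assay and not a number. Compound 3 also stands at a limit, so no step can be read between compound 3 and compound 4. The compounds shown leave open how far either half-life lies past the limit, and whether isopropyl in place of neopentyl changes it at all.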